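A few compounds are considered here, and "the series" means these few. Any claim that something is new, unique, unknown or untested is made for them only; others in the source may bear on it.

Compound 1 `COc1cc(/C=C/C(=O)C2=C(/C=C/c3ccc(O)c(OC)c3)NC(=O)NC2c2ccc(O)cc2)ccc1O` gives 90.3% in a functional assay, with a stated time of 20 min, tested at 50 uM (on this read-out lower numbers stand for a weaker effect and higher numbers for a stronger effect at the one concentration tested), and compound 2 `COc1cc(/C=C/C(=O)C2=C(/C=C/c3ccc(O)c(OC)c3)NC(=O)NC2c2ccc(N(C)C)cc2)ccc1O` gives 56%, the lowest of the two numbers; its nearest neighbour is compound 1, reached by a number 34.3 percentage points lower from compound 1 to compound 2 (beyond the scatter). Compound 3 `COc1cc(/C=C/C(=O)C2=C(/C=C/c3ccc(O)c(OC)c3)NC(=O)NC2c2cccc([N+](=O)[O-])c2)ccc1O` differs from compound 2 by 3-nitrophenyl in place of 4-(dimethylamino)phenyl on a saturated ring carbon. Among the compounds with values here, only one measured step touches this position, and it was large, but no measured step carries the 3-nitrophenyl group, so the direction is uncertain. Compound 3 is therefore expected to show a modest rise, a number 9 percentage points higher from compound 2 to compound 3 (within the scatter), giving an estimated 65% with a range from 35% to 92%.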

Compound 3, a percentage reported as activity, at one concentration (the size of the read-out at that concentration, not a potency): 71%
Estimate against measurement, compound 3: 6 percentage points below; low and high end bracket the measured number.
By their numbers in this assay, from the lowest: compound 2; then compound 3; then compound 1.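

In this assay the saturated ring carbon now carries a third aryl group, and 3-nitrophenyl falls at neither end of the series (a number 15 percentage points higher from compound 2 to compound 3 (beyond the scatter)) and (a number 19.3 percentage points lower from compound 1 to compound 3 (beyond the scatter)). An aryl group with neither hydroxy nor dimethylamino thus keeps more of the read-out than 4-(dimethylamino)phenyl, yet stays short of 4-hydroxyphenyl. Nothing available here accounts for this order. The compounds shown leave open whether the place of the nitro group on the ring matters, and how a 3-hydroxyphenyl, a 4-nitrophenyl or a carboxylic acid on this aryl ring would read.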